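Ring-size pair and one methyl on the lactam nitrogen

The compounds below may be only part of what the source reports. "The series", "measured", "known", "first", "only" and "open" are said of these compounds alone.

Three compounds have been measured in a functional assay on the whole organism with Mus musculus as the target; on this read-out higher numbers stand for an effect only at larger amounts of compound and lower numbers for an effect already at smaller amounts:

Compound 1, `O=C1CC[C@@H](NC(=O)OCc2ccccc2)C(=O)N1`, gives 46.9 mg/kg.
Compound 2, `CN1C(=O)CC[C@@H](NC(=O)OCc2ccccc2)C1=O`, gives 24.4 mg/kg.
Compound 3, `O=C1C[C@H](NC(=O)OCc2ccccc2)C(=O)N1`, gives 78.1 mg/kg.

Compound 1 and compound 2 share a core and differ by methyl in place of hydrogen on an amide-type nitrogen in a ring. In this assay that change made a 1.9-fold lower number from compound 1 to compound 2 (0.28 log units; within the scatter), so the two values cannot be ranked with confidence. Compound 3 carries a different core; the difference between the two cores is not broken down here. Against compound 3, compound 1 sits within the scatter, whereas compound 2 lies beyond it.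

Compound 4, `CN1C(=O)C[C@H](NC(=O)OCc2ccccc2)C1=O`, has not yet been measured. It differs from compound 3 by methyl in place of hydrogen on an amide-type nitrogen in a ring. This is the same kind of change as that from compound 1 to compound 2, though not the same: there the methyl enters on an amide-type nitrogen in a ring of a six-membered non-aromatic ring with 1 nitrogen, here on an amide-type nitrogen in a ring of a five-membered non-aromatic ring with 1 nitrogen, in both cases two ring bonds from the ring atom that bears a large group.

Since the earlier methylation gave only a 1.9-fold lower number from compound 1 to compound 2 (0.28 log units; within the scatter), a step of similar size is expected for compound 4, namely a 1.7-fold lower number from compound 3 to compound 4 (0.24 log units; within the scatter). Compound 4 is therefore estimated at 45 mg/kg in this assay, with a range from 20 mg/kg to 100 mg/kg.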

Compound 4, dose for half-maximal effect: 113 mg/kg
Beside the measured number, compound 4's estimate is 2.5-fold (0.40 log units) below it; measured number outside the range, above it.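

On the core of compound 3, methyl in place of hydrogen on an amide-type nitrogen in a ring gave a 1.4-fold higher number from compound 3 to compound 4 (0.16 log units; within the scatter) in this assay, so compound 3 and compound 4 cannot be ranked against each other. Set beside the earlier step, the change does not carry over from one core to the other as a step of fixed size: the same change on two cores in this assay, a 1.9-fold lower number (0.28 log units; within the scatter) from compound 1 to compound 2 and a 1.4-fold higher number (0.16 log units; within the scatter) from compound 3 to compound 4, 2.8-fold (0.44 log units) apart, beyond the scatter of two such steps Taken alone, neither step shows a reliable effect of the methyl, and two pairs show only that the outcome of this change differed between these two cores, not which feature of the cores goes with that difference or how the change would behave on any further core.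

The compounds shown carry only hydrogen or methyl on the ring nitrogen, which leaves open whether an ethyl group or a longer chain there would give steps that clearly separate from the parent compounds on either core. On these data alone, all four compounds also share the same benzyl carbamate, so it remains open how the two cores would compare with an amine or a carboxylic acid in its place.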